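The source may hold more compounds than are shown below. What is called first, only, known or untested is meant among the compounds shown, and "the series" means these compounds.

In an ADME assay (liver) for metabolic stability, with Liver microsome (Canis lupus familiaris) as the target, read by LC-MS, using microsomes, with a stated time of 30 min, tested at 4 uM (on this read-out lower numbers stand for a less stable compound and higher numbers for a more stable compound), compound 1 (`Cc1nc(N2CCN(C)CC2)c2nc(-c3ccccc3Cl)n(CCO)c2n1`) gives 99%, the highest of the three measured numbers, ahead of compound 2 (`CCN1CCN(c2nc(C)nc3c2nc(-c2ccccc2Cl)n3CCOC)CC1`) at 86% and compound 3 (`COCCn1c(-c2ccccc2Cl)nc2c(N3CCN4C(=O)CCC4C3)nc(C)nc21`) at 35%. Compound 4 (`Cc1nc(N2CCN(C)CC2)c2nc(-c3ccccc3Cl)n(CCN3CCCC3=O)c2n1`) differs from compound 1 by 2-oxopyrrolidin-1-yl in place of hydroxy on a saturated chain carbon, two bonds along the chain from an aromatic nitrogen. For the measured compounds named here, one measured step bears on this change: a number 51 percentage points lower from compound 2 to compound 3 (beyond the scatter). That large step also brings in a five-membered non-aromatic ring with 1 hetero atom, but on an aromatic carbon rather than a saturated chain carbon, so it offers only a loose guide. A smaller fall is therefore expected, and the estimated step is a number 31 percentage points lower from compound 1 to compound 4 (beyond the scatter). For compound 4, the expected value is 68%, with an estimated range of 42% to 92%.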

Compound 4, percent of the compound remaining: 60%
Estimate against measurement, compound 4: 8 percentage points above; the range from low to high includes it.
By their numbers in this assay, from the lowest: compound 3; then compound 4; then compound 2; then compound 1.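

In this assay, 2-oxopyrrolidin-1-yl in place of hydroxy on a saturated chain carbon, two bonds along the chain from an aromatic nitrogen, gives a number 39 percentage points lower from compound 1 to compound 4 (beyond the scatter). The earlier large fall, a number 51 percentage points lower from compound 2 to compound 3 (beyond the scatter), came on an aromatic carbon, so this result shows that this chain position also responds strongly to a change of group. Nothing available explains the fall. Still open, going by these compounds, is whether it follows from losing hydroxy or from gaining the ring, and how a dimethylamino group or a carboxylic acid on the same chain would stand.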